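Replacing a furan ring with pyrrolidine on a shared core

This account rests on a few compounds, and the source may have more. Where it says the series, first, only, none or still open, it means among the compounds named here.

Of the compounds shown here, three sharing one core have been tested in an ADME assay on HEL cells (Homo sapiens) for cytotoxicity, with a stated time of 3 days; on this read-out lower numbers stand for higher toxicity in this test and higher numbers for lower toxicity in this test. Compound 1 `Cc1cc(-c2ccc(C=O)cc2)cn2c(CSCCc3ccccc3)cnc12` gives 100 ug/mL in this assay. Going by the values given here, compound 2 `Cc1cc(Sc2ccc(O)cc2)cn2c(CSCCc3ccccc3)cnc12` gives 4 ug/mL, and the one measured step, a 25-fold lower number from compound 1 to compound 2 (1.40 log units; beyond the scatter), is the only change in this set that moves the number beyond the scatter. Compound 3 `Cc1cc(-c2ccco2)c2ncc(CSCCc3ccccc3)n2c1` gives 100 ug/mL, which stands level with compound 1 at the digits shown; the two are together the highest of the three numbers, while compound 2 lies a long way below both.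

Compound 4 `Cc1cc(N2CCCC2)c2ncc(CSCCc3ccccc3)n2c1` differs from compound 3 in a single place: pyrrolidin-1-yl in place of furan-2-yl on an aromatic carbon. Among the compounds with values here, no measured step concerns this change. The step from compound 1 to compound 2 alters a different group, a (4-hydroxyphenyl)sulfanyl entering for a 4-formylphenyl, and so cannot be read as a guide to a pyrrolidin-1-yl entering for a furan-2-yl. With nothing in the data pointing either way, compound 4 is expected to stay close to compound 3, and the expected step is no change at the digits printed from compound 3 to compound 4 (within the scatter), within the scatter. On this basis compound 4 is estimated at 100 ug/mL in this assay, with a range from 25 ug/mL to 100 ug/mL.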

Compound 4, minimum cytotoxic concentration: > 100 ug/mL
Compound 4: only a limit was reported (the forecaster's own chance of this, stated with the estimate: 35%); the middle value sits exactly at the limit.
By their numbers in this assay, from the lowest: compound 2; then compounds 1 and 3 (each within the scatter of the next).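

In this assay, the change on this aromatic carbon gives a number no lower from compound 3 to compound 4 (the limit leaves the size open), so the non-aromatic pyrrolidin-1-yl, with its ring nitrogen, takes the place of the aromatic furan-2-yl without any fall in the number. Compound 4 gives > 100 ug/mL, which is a limit and not a number, so the size of the step cannot be read: the limit of > 100 ug/mL in this assay, at which 1 of the 4 values shown sits. Going by these compounds alone, the earlier compounds showed only furan-2-yl at this position and a single large drop that belonged to a different change, whereas this result is the first sign that the position accepts a second kind of five-membered ring while the read-out stays at the top of the values shown.

On these data alone, whether an open-chain amine such as dimethylamino, a morpholin-4-yl ring or a carboxylic acid on this carbon would also leave the number at the limit remains open. As far as these compounds go, it is equally open whether the same exchange of furan-2-yl for pyrrolidin-1-yl would leave the number unlowered with an ethyl group in place of the methyl group on the six-membered ring.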